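From Dimethoxyphenyl to Dichlorophenyl: Estimating Growth Inhibition

The source may hold more compounds than are shown below. What is called first, only, known or untested is meant among the compounds shown, and "the series" means these compounds.

Of the compounds shown here, two sharing one core have been measured so far in a functional assay on UACC-62 cells (Homo sapiens) for inhibition, read by sulforhodamine B assay, with a stated time of 48 h; on this read-out higher numbers stand for weaker inhibition of growth and lower numbers for stronger inhibition of growth. Compound 1 `O=C(Cc1csc2nc(-c3ccc(Br)cc3)cn12)N/N=C/c1ccccc1O`, which carries a 2-hydroxyphenyl group, gives 7240 nM, and compound 2 `COc1cccc(OC)c1/C=N/NC(=O)Cc1csc2nc(-c3ccc(Br)cc3)cn12`, which carries a 2,6-dimethoxyphenyl group, gives 27500 nM. Compound 2 therefore holds the higher of the two numbers and is the weaker growth inhibitor of the pair. The unmeasured compound 3 `O=C(Cc1csc2nc(-c3ccc(Br)cc3)cn12)N/N=C/c1ccc(Cl)cc1Cl` keeps the core and changes one group: 2,4-dichlorophenyl in place of 2,6-dimethoxyphenyl on a carbon with a double bond to nitrogen. Within the data shown here, only one measured step involves this place, a 3.8-fold higher number from compound 1 to compound 2 (0.58 log units; beyond the scatter), and it is modest. Among the measured compounds shown here, no compound with a chlorine-bearing group has been measured, so this guide is thin. With compound 2 at 27500 nM, the top of a very short range, a modest step toward a lower number in this assay seems likelier than a further rise. The expected change is a 2.1-fold lower number from compound 2 to compound 3 (0.33 log units; beyond the scatter). Compound 3 is estimated at 13000 nM, with an expected range of 5000 nM to 40000 nM.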

Compound 3, concentration for total growth inhibition: 67600 nM
Compound 3: the middle estimate sits 5.2-fold (0.72 log units) below what was measured; measured number outside the range, above it.
By their numbers in this assay, from the lowest: compound 1; then compound 2; then compound 3.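

In this assay the swap to 2,4-dichlorophenyl gives a 2.5-fold higher number from compound 2 to compound 3 (0.39 log units; beyond the scatter) and so shows that replacing the 2,6-dimethoxyphenyl group does not necessarily lower the number: at this position on the carbon with a double bond to nitrogen, the change moved growth inhibition further in the weaker direction. Set against the 2-hydroxyphenyl group, the same entering group gives a 9.3-fold higher number from compound 1 to compound 3 (0.97 log units; beyond the scatter) and widens the span seen at this one position, with compound 1 now the strongest growth inhibitor of the three and compound 3 the weakest. Nothing available explains why the three groups fall in this order.

The three groups differ in more than one feature at once, so these compounds cannot show which feature of each group goes with its place in the order. Going by these compounds, it remains open where a plain phenyl ring, or a phenyl ring carrying an amine or a carboxylic acid, would fall relative to compound 1 and compound 3, and whether the same order would hold if the 4-bromophenyl group on the shared core were replaced.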